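The source may report more compounds than this note shows. Statements on the series, on what has been measured and on what is new or still open speak of the compounds shown alone.

Compound 1 `O=C(/C=C/C=C/c1ccccc1[N+](=O)[O-])N1CCN(C2CCCC2)CC1` is one of two compounds with a number in a functional assay on cells (Platelet, Homo sapiens) for inhibition; a lower number here means a less potent compound, a higher number a more potent compound, by a factor of ten per unit of this negative logarithm. In this assay compound 1 gives 5.5. Within the data shown here, the only other measured compound, compound 2 `O=C(/C=C/c1ccccc1[N+](=O)[O-])N1CCN(CC2CCCCC2)CC1`, gives in this assay 5.31, and the two numbers lie within the usual scatter of each other, so the data show no separation between them. Among the measured compounds shown here, no step between measured compounds that differ in a single place is available, and nothing here tells how a change on the amine nitrogen in the ring shifts the read-out.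

Compound 3 `O=C(/C=C/C=C/c1ccccc1[N+](=O)[O-])N1CCN(c2ccccc2)CC1` has not yet been measured in this assay. It differs from compound 1 by phenyl in place of cyclopentyl on an amine nitrogen in a ring. For the measured compounds named here, with no comparable step to lean on, the expected change from compound 1 to compound 3 is small, a number 0.10 log units lower from compound 1 to compound 3 (within the scatter), in no particular direction beyond the scatter. Compound 3 is accordingly estimated at 5.4 in this assay, with a range from 4.7 to 6.1.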

Compound 3, negative logarithm of the antagonist equilibrium constant: 5.65
Compound 3: middle estimate off by 0.25 log units, on the low side; the range from low to high includes it.
By their numbers in this assay, from the lowest: compounds 2, 1 and 3 (each within the scatter of the next, the first and the last beyond it).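

Among these compounds, this is the first step that can be read at the amine nitrogen in the ring: in this assay, phenyl in place of cyclopentyl gives a number 0.15 log units higher from compound 1 to compound 3 (within the scatter), so the data do not separate the two groups at this place. An aromatic six-membered ring of carbon and a non-aromatic five-membered ring of carbon thus read alike here on the core of compound 1, although this is a single pair. Nothing available bears on why the two groups read alike.

On these data alone, whether any group on this nitrogen can move the number beyond the scatter remains open. A benzyl group, a pyridyl ring or a chain ending in a carboxylic acid would test this, and the compounds shown say nothing about them.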